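Working notes: from compound 1 to compound 4

A few compounds are considered here, and "the series" means these few. Any claim that something is new, unique, unknown or untested is made for them only; others in the source may bear on it.

compound 1 `O=C(Nc1ccccc1F)Nc1cc2ncncc2cc1OCc1ccccc1` gives 4500 nM
compound 2 `O=C(Nc1ccccc1F)Nc1cc2ncncc2cc1OCc1ccccc1F` gives 3600 nM
compound 3 `O=C(Nc1ccccc1F)Nc1cc2ncncc2cc1OCc1cccc(Cl)c1` gives 4400 nM

In a functional assay on GBM2 cells (Homo sapiens) for antiproliferative activity, read by WST assay, with a stated time of 72 h (a lower number here means a stronger inhibitor, a higher number a weaker inhibitor), compound 1 stands level with the other two measured compounds. The steps of a 1.3-fold lower number from compound 1 to compound 2 (0.10 log units; within the scatter) and a 1.0-fold lower number from compound 1 to compound 3 (0.01 log units; within the scatter) both lie within the scatter, so no order can be read among the three.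

The next compound is compound 4 `O=C(Nc1cccc(Cl)c1)Nc1cc2ncncc2cc1OCc1ccccc1`, which is still unmeasured. Its difference from compound 1 is 3-chlorophenyl in place of 2-fluorophenyl on an amide-type nitrogen. In words, this is 3-chlorophenyl in place of 2-fluorophenyl on an amide-type nitrogen.

The closest evidence is the same exchange of groups at another place, on a saturated chain carbon bound to an oxygen on an aromatic ring: a 1.2-fold higher number from compound 2 to compound 3 (0.09 log units; within the scatter). That step is also within the scatter. However, no measured compound varies the group on the amide-type nitrogen, so this evidence is indirect and the range is kept wide.

No step beyond the scatter is therefore expected in this assay. The estimated step is a 1.1-fold lower number from compound 1 to compound 4 (0.05 log units; within the scatter). For compound 4 the expected value is 4000 nM, with an estimated range from 1300 nM to 10000 nM.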

Compound 4, half-maximal inhibitory concentration: 4100 nM
Compound 4: the middle estimate sits 1.0-fold (0.01 log units) below what was measured; the measured number falls inside the stated range.
By their numbers in this assay, from the lowest: compounds 2, 4, 3 and 1 (each within the scatter of the next).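

In this assay, among the compounds shown here, the group on the amide-type nitrogen is now varied for the first time, and a 1.1-fold lower number from compound 1 to compound 4 (0.04 log units; within the scatter) shows that 3-chlorophenyl in place of 2-fluorophenyl at this place leaves the number level with that of compound 1. The same exchange of groups on the saturated chain carbon bound to an oxygen on an aromatic ring also stays within the scatter, at a 1.2-fold higher number from compound 2 to compound 3 (0.09 log units; within the scatter), so among these four compounds it has no readable effect at either place, and no compound goes against this. Nothing shown bears on why the numbers stay level.

The compounds shown leave open how the number responds on the amide-type nitrogen to anything other than a halogen-bearing phenyl, such as a phenyl carrying a dimethylamino group or a carboxylic acid, or a plain alkyl chain in place of the ring. Every step shown lies within the scatter, and whether any change at either place can move the number beyond it remains an open question.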